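The source may report more compounds than this note shows. Statements on the series, on what has been measured and on what is new or still open speak of the compounds shown alone.

Three thiosemicarbazones share one core and differ only in the aromatic group attached to the carbon with a double bond to nitrogen. Compound 1 `CC1=CC[C@@H]([C@@](C)(O)CCCC(C)(C)NC(=S)N/N=C\c2ccccc2)CC1` carries a plain phenyl; in a functional assay on OVCAR-3 cells (Homo sapiens) for cytotoxicity, read by sulforhodamine B assay (on this read-out lower numbers stand for stronger inhibition of growth and higher numbers for weaker inhibition of growth), compound 1 gives 6970 nM. Compound 2 `CC1=CC[C@@H]([C@@](C)(O)CCCC(C)(C)NC(=S)N/N=C\c2ccc(C)cc2)CC1` carries a 4-methylphenyl, and in this assay compound 2 gives 6020 nM. Compound 3 `CC1=CC[C@@H]([C@@](C)(O)CCCC(C)(C)NC(=S)N/N=C\c2cccc([N+](=O)[O-])c2)CC1` carries a 3-nitrophenyl, and in this assay compound 3 gives 8510 nM. Compound 2 has the lowest of the three numbers, yet every step to it lies within the scatter: a 1.2-fold lower number from compound 1 to compound 2 (0.06 log units; within the scatter), a 1.2-fold higher number from compound 1 to compound 3 (0.09 log units; within the scatter) and a 1.4-fold higher number from compound 2 to compound 3 (0.15 log units; within the scatter). The aromatic substituent has so far made no difference that can be trusted.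

Compound 4 `CC1=CC[C@@H]([C@@](C)(O)CCCC(C)(C)NC(=S)N/N=C\c2cccc(Cl)c2)CC1` is the next variation: 3-chlorophenyl in place of 4-methylphenyl on a carbon with a double bond to nitrogen. The step from compound 2 to compound 3, which also exchanges the whole aromatic group at this carbon, bears most directly on it, and it stayed within the scatter. He therefore expects no step beyond the scatter, a 1.2-fold higher number from compound 2 to compound 4 (0.07 log units; within the scatter). For compound 4 in this assay he estimates 7000 nM, with a range from 3500 nM to 14000 nM.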

Compound 4, concentration for 50% growth inhibition: 8270 nM
The estimate for compound 4 lay 1.2-fold (0.07 log units) below the measured number; the measured number falls inside the stated range.
By their numbers in this assay, from the lowest: compounds 2, 1, 4 and 3 (each within the scatter of the next).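

With compound 4, a halogen joins the groups tried on the carbon with a double bond to nitrogen, and the result is again a step within the scatter in this assay: a 1.4-fold higher number from compound 2 to compound 4 (0.14 log units; within the scatter). Two further comparisons stay within the scatter as well, since adding a chloro group to the plain phenyl gives a 1.2-fold higher number from compound 1 to compound 4 (0.07 log units; within the scatter) and the direct exchange of nitro for chloro gives a 1.0-fold lower number from compound 3 to compound 4 (0.01 log units; within the scatter), so none of the steps among these four compounds can be read as a real difference. No measurement is available that would explain this lack of separation.

The compounds shown leave open whether an amine or a carboxylic acid on the aromatic group would produce a step beyond the scatter. They also leave open whether any change to the shared core, such as replacing its hydroxyl group, would matter more than these aromatic exchanges.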